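Methoxy in place of nitro on a cinnamate-type scaffold

The source may hold more compounds than are shown below. What is called first, only, known or untested is meant among the compounds shown, and "the series" means these compounds.

Compound 2 `O=C(O)C1=Cc2ccccc2OC1(OCc1cc(-c2ccc([N+](=O)[O-])cc2)no1)C(F)(F)F` shows only a limit in a functional assay on A549 cells (Homo sapiens) for inhibition, read by MTT assay, with a stated time of 24 h (on this read-out higher numbers stand for weaker inhibition and lower numbers for stronger inhibition), given as > 150000 nM. Its two neighbours stand the same way. In this assay compound 1 `CCOC(=O)C1=Cc2ccccc2OC1(OCc1cc(-c2ccc(OC)cc2)no1)C(F)(F)F` gives a limit of > 150000 nM. Compound 3 `CCOC(=O)C1=Cc2ccccc2OC1(OCc1cc(-c2ccc([N+](=O)[O-])cc2)no1)C(F)(F)F` likewise gives a limit of > 150000 nM. Accordingly the limit of > 150000 nM in this assay, at which 3 of the 3 values shown sit, is all the evidence there is. Compound 4 `COc1ccc(-c2cc(COC3(C(F)(F)F)Oc4ccccc4C=C3C(=O)O)on2)cc1` differs from compound 2 by methoxy in place of nitro on an aromatic carbon. The closest measured comparison is a step that the two limits leave unreadable from compound 1 to compound 3, the same swap run backwards on the ethyl ester, and a step that the two limits leave unreadable from compound 2 to compound 3 is no more readable; both are hidden by the limit. Within the data shown here, no step of readable size therefore points in any direction, and compound 4 is expected to stay near the limit, with a step that the limit leaves unreadable from compound 2 to compound 4 as the estimated step. The value for compound 4 is estimated at 200000 nM, between 80000 nM and 500000 nM.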

Compound 4, half-maximal inhibitory concentration: 36200 nM
Compound 4: middle estimate off by 5.5-fold (0.74 log units), on the high side; the measured number lies below the stated range.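

In this assay, the 4-methoxyphenyl group and the free carboxylic acid together give the first readable number. Each change counts on its own terms: methoxy in place of nitro gives a clear gain in strength (an at least 4.1-fold lower number from compound 2 to compound 4 (0.61 log units; beyond the scatter)), and hydrogen in place of ethyl on the ester does too (an at least 4.1-fold lower number from compound 1 to compound 4 (0.61 log units; beyond the scatter)). The steps among compounds 1, 2 and 3 cannot be read, since all three values are limits, so only the pairing of methoxy with the acid stands out here.

On these data alone, how far the gain would go with a chlorine or an amine in place of methoxy stays open. So does whether an amide could stand in for the carboxylic acid.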